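Dropping the benzyloxy group: compound 2 to compound 3

The source may report more compounds than this note shows. Statements on the series, on what has been measured and on what is new or still open speak of the compounds shown alone.

Compound 1 `CCSc1nn2cc(-c3cc4ccccc4o3)nc2s1` is recorded in an assay for antagonist activity at proteinase-activated receptor 4 (Homo sapiens), with stated times of 5 min, 50 s and 15 min, in the presence of a further agent that is not named here (a lower number here means a stronger inhibitor, a higher number a weaker inhibitor), only as "not determined" (no result reported), with no number. Going by the values given here, compound 2 `COc1nn2cc(-c3cc4ccc(OCc5ccccc5)cc4o3)nc2s1` is the only member with a number: in this assay compound 2 gives 1800 nM, so it stands alone and cannot be ranked against anything. Compound 3 `COc1nn2cc(-c3cc4ccccc4o3)nc2s1` differs from compound 2 by hydrogen in place of benzyloxy on an aromatic carbon. Among the compounds with values here, no step between measured compounds exists, so the size of this change is open. With nothing to lean on, a weakening beyond the scatter is expected rather than a gain. Compound 3 is expected at 3500 nM, between 900 nM and 14000 nM. The expected step of a 1.9-fold higher number from compound 2 to compound 3 (0.29 log units; within the scatter) is a loss in this assay.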

Compound 3, half-maximal inhibitory concentration: 240 nM
Compound 3: middle estimate off by 15-fold (1.16 log units), on the high side; measured number outside the range, below it.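

In this assay, hydrogen in place of benzyloxy on the aromatic carbon gives a 7.5-fold lower number from compound 2 to compound 3 (0.88 log units; beyond the scatter), so this is a gain rather than a loss. For this pair, the benzyloxy group is not required for inhibition, and the unsubstituted position gives the stronger inhibitor. No measured evidence here bears on the reason for this step.

Only benzyloxy and hydrogen are compared at this carbon, so the effect of the change cannot be called a trend. From the compounds shown here alone, whether a fluorine atom, a hydroxyl group or a shorter alkoxy chain would match compound 3 remains open.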